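Compound 3 to compound 4: a step beyond the limit

The source may hold more compounds than are shown below. What is called first, only, known or untested is meant among the compounds shown, and "the series" means these compounds.

Measured in a functional assay on MCF7 cells (Homo sapiens) for antiproliferative activity, read by MTT assay, with a stated time of 48 h; on this read-out higher numbers stand for weaker inhibition and lower numbers for stronger inhibition:
- compound 1 `C=CCN(C)C(=O)c1ccc(C(CC)(CC)c2ccc(OCCC(O)(CC)CC)c(C)c2)n1CC`: > 50000 nM
- compound 2 `CCn1c(C(=O)Nc2ccc(OC(F)(F)F)cc2)ccc1C(CC)(CC)c1ccc(OCCC(O)(CC)CC)c(C)c1`: > 50000 nM
- compound 3 `CCOc1ccc(NC(=O)c2ccc(C(CC)(CC)c3ccc(OCCC(O)(CC)CC)c(C)c3)n2CC)cc1`: > 50000 nM

Each of these entries is a limit of the assay and not a number. Compound 3 stands at > 50000 nM, which is likewise only a limit. All three measured compounds share one reading: the limit of > 50000 nM in this assay, at which 3 of the 3 values shown sit. Compound 3 therefore offers no numerical starting point.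

Compound 4 `CCC(C)C(CO)NC(=O)c1ccc(C(CC)(CC)c2ccc(OCCC(O)(CC)CC)c(C)c2)n1CC` carries 1-(hydroxymethyl)-2-methylbutyl in place of 4-ethoxyphenyl on an amide-type nitrogen. The shared core stays the same, while the entering group has no ring.

The nearest measured evidence is a step that the two limits leave unreadable from compound 1 to compound 3, which changes the amino group on the same carbonyl carbon. a step that the two limits leave unreadable from compound 1 to compound 2 makes a change at that carbon too, and a step that the two limits leave unreadable from compound 2 to compound 3 alters only the group on the oxygen. None of the three has a readable size, so none gives a measured size or direction for the new change. In this assay, among the compounds with values here, no step of readable size is expected in either direction, and compound 4 is expected to stay at the limit. The expected step is a number no higher from compound 3 to compound 4 (the limit leaves the size open). For compound 4 the estimated value is 50000 nM, with an expected range of 20000 nM to 100000 nM.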

Compound 4, half-maximal inhibitory concentration: 29100 nM
Compound 4: middle estimate off by 1.7-fold (0.24 log units), on the high side; low and high end bracket the measured number.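

In this assay, within the data shown here, compound 4 gives 29100 nM, the only reading in this set that is a number and not a limit, so a group with no ring on the amide-type nitrogen can bring the series into the measurable range. The replacement of the aryl groups by 1-(hydroxymethyl)-2-methylbutyl reads as an at least 1.7-fold lower number from compound 3 to compound 4 (0.23 log units; that floor lies within the scatter) and as an at least 1.7-fold lower number from compound 2 to compound 4 (0.23 log units; that floor lies within the scatter), and the change of the whole amino group on the carbonyl carbon reads as an at least 1.7-fold lower number from compound 1 to compound 4 (0.23 log units; that floor lies within the scatter). These are floors only, so a number now exists for this position but no change beyond the scatter is shown, and the steps among the other three compounds cannot be read, as they all remain at the same assay limit: the limit of > 50000 nM in this assay, at which 3 of the 4 values shown sit.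

On these data alone, the true size of the step remains open, as does the question of whether the hydroxymethyl part or the branched chain of the new group accounts for the reading. Also open, as far as these compounds go, is how a plain 2-methylbutyl chain, an amine or a carboxylic acid on this nitrogen would read in this assay.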